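This account rests on a few compounds, and the source may have more. Where it says the series, first, only, none or still open, it means among the compounds named here.

Measured compounds:
- compound 1 `COC(=O)c1c([N+](=O)[O-])noc1-c1ccccc1`: "not determined" (no result reported)
- compound 2 `COC(=O)c1c(NCCCCNc2ccnc3cc(Cl)ccc23)noc1-c1ccc([N+](=O)[O-])cc1`: 136000 nM

In an ADME assay on J774.A1 cells (Mus musculus) for cytotoxicity, read by MTT assay, with a stated time of 48 h (on this read-out lower numbers stand for higher toxicity in this test and higher numbers for lower toxicity in this test), compound 2 gives 136000 nM. Among the compounds with values here, this is the only number, so it cannot yet be ranked, and compound 1 offers no comparison. Compound 3 `COC(=O)c1c(NCCCCNc2ccnc3cc(Cl)ccc23)noc1-c1ccccc1[N+](=O)[O-]` is an isomer of compound 2: 2-nitrophenyl in place of 4-nitrophenyl on an aromatic carbon. The 2-nitrophenyl replaces the 4-nitrophenyl on the same aromatic carbon, next to the ring oxygen. Within the data shown here, no measured step exists to size this change, so no shift beyond the scatter is expected, and no direction can be assigned with confidence. The expected change is small, a 1.2-fold lower number from compound 2 to compound 3 (0.09 log units; within the scatter). Compound 3 is estimated at 110000 nM, within a range of 45000 nM to 250000 nM.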

Compound 3, half-maximal cytotoxic concentration: 77700 nM
Compound 3: middle estimate off by 1.4-fold (0.15 log units), on the high side; the measured number falls inside the stated range.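

In this assay, within the data shown here, the first measured step at this position is a 1.8-fold lower number from compound 2 to compound 3 (0.24 log units; within the scatter). Placing 2-nitrophenyl in place of 4-nitrophenyl on this aromatic carbon, next to the ring oxygen, therefore leaves compound 2 and compound 3 within the usual scatter of each other. No supporting data bear on this result.

On these data alone, whether an amine in place of the nitro group on this phenyl ring would shift the number beyond the scatter remains open. The same holds for a carboxylic acid in place of the methoxycarbonyl group.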